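This account rests on a few compounds, and the source may have more. Where it says the series, first, only, none or still open, it means among the compounds named here.

Measured so far in an assay on isolated protein (Cricetulus griseus) for binding affinity to Alpha-1B adrenergic receptor (Mesocricetus auratus), read by radioligand binding; on this read-out higher numbers stand for weaker inhibition and lower numbers for stronger inhibition:
Compound 1 `CN(c1cccc2c1CCCC2c1c[nH]cn1)S(C)(=O)=O` gives < 10000 nM, a limit of the assay rather than a number.
Compound 2 `O=C(Nc1cccc2c1CCCC2c1c[nH]cn1)C(F)(F)F` gives < 10000 nM, likewise a limit of the assay.

Within the data shown here, compound 2 therefore stands only on a limit in this assay; the one other value shown is also a limit, so no ranking between the two is possible. Among the measured compounds shown here, the single measured step, a step that the two limits leave unreadable from compound 1 to compound 2, is unreadable for the same reason, as the limit of < 10000 nM in this assay, at which 2 of the 2 values shown sit, states.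

Compound 3 `Oc1cccc2c1CCCC2c1c[nH]cn1` is compound 2 with hydroxy in place of ((trifluoromethyl)carbonyl)amino on an aromatic carbon. For the measured compounds named here, no measured step bears on this change: the only step in the set swaps one amide-like substituent for a sulfonamide, and its size cannot be read. The expectation for this assay thus rests on nothing more than the fact that compound 2 sits inside the limit, so compound 3 is estimated to sit there as well, with the step that the limit leaves unreadable from compound 2 to compound 3 treated as undetermined in direction. Compound 3 is expected near 600 nM, within the range 30 nM to 10000 nM, and a further limit report is a real possibility.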

Compound 3, inhibition constant: 145 nM
Beside the measured number, compound 3's estimate is 4.1-fold (0.62 log units) above it, and the stated range covers the measured number.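

In this assay the steps from compound 1 and from compound 2 to compound 3 cannot be read, because compound 1 and compound 2 stand only on limits: the limit of < 10000 nM in this assay, at which 2 of the 3 values shown sit.

The compounds shown leave open how compound 3 truly ranks against compound 1 and compound 2, and so what size or direction either hydroxy replacement has.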